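Chloro to Fluoro: Cytotoxicity Step Toward Compound 3

The compounds below may be only part of what the source reports. "The series", "measured", "known", "first", "only" and "open" are said of these compounds alone.

Compound 2 `OB1OCc2ccc(-n3cc(Sc4ccc(Cl)cc4)c4ccccc43)cc21` carries a (4-chlorophenyl)sulfanyl group on the shared core. In an ADME assay on L929 cells (Mus musculus) for cytotoxicity, read by resazurin assay, with a stated time of 72 h (on this read-out higher numbers stand for weaker inhibition and lower numbers for stronger inhibition), compound 2 gives > 10 ug/mL, which is a limit of the assay rather than a number. Compound 1 `OB1OCc2ccc(-n3cc(Sc4ccc(Cl)c(Cl)c4)c4ccccc43)cc21` likewise reaches only a limit: in this assay compound 1 gives > 10 ug/mL. The step from compound 1 to compound 2 is a step that the two limits leave unreadable from compound 1 to compound 2 because both values sit at the limit of > 10 ug/mL in this assay, at which 2 of the 2 values shown sit. Compound 3 `OB1OCc2ccc(-n3cc(Sc4ccc(F)cc4)c4ccccc43)cc21` differs from compound 2 by fluoro in place of chloro on an aromatic carbon. Going by the values given here, no measured step can size this change. Compound 3 is expected near the same limit, estimated at 15 ug/mL with a range from 6 ug/mL to 40 ug/mL. The expected step is a step that the limit leaves unreadable from compound 2 to compound 3.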

Compound 3, half-maximal inhibitory concentration: > 10 ug/mL
Compound 3 ended at the assay's limit; the forecaster's own chance of this, stated with the estimate: 80%; the middle value does not contradict the limit.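

In this assay, going by these compounds alone, no step among compound 1, compound 2 and compound 3 can be read, because each value is a limit of the assay and not a number: the limit of > 10 ug/mL in this assay, at which 3 of the 3 values shown sit.

The compounds shown leave open how strongly any of the three acts on these cells, and whether the change from chloro to fluoro alters that at all.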